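Chloro for methyl on the aryl-triazole arm of two cores

The source may report more compounds than this note shows. Statements on the series, on what has been measured and on what is new or still open speak of the compounds shown alone.

Compound 1 `C=C1C(=O)[C@]23C[C@@]1(O)CC[C@H]2c1ccc(OS(=O)(=O)c2ccc(C)cc2)c(C)c1[C@@H]3Cn1cc(-c2ccc(Cl)cc2)nn1` and compound 2 `C=C1C(=O)[C@]23C[C@@]1(O)CC[C@H]2c1ccc(OS(=O)(=O)c2ccc(C)cc2)c(C)c1[C@@H]3Cn1cc(-c2ccc(C)cc2)nn1` share one core; compound 3 `C=C1C[C@]23C[C@@]1(O)CC[C@H]2c1cc(Br)c(O)c(C)c1[C@@H]3Cn1cc(-c2ccc(C)cc2)nn1` and compound 4 `C=C1C[C@]23C[C@@]1(O)CC[C@H]2c1cc(Br)c(O)c(C)c1[C@@H]3Cn1cc(-c2ccc(Cl)cc2)nn1` share another, and the difference between the two cores is not broken down here. In a functional assay on SMMC-7721 cells (Homo sapiens) for cytotoxicity, read by MTT assay, with a stated time of 4 days (on this read-out lower numbers stand for stronger inhibition and higher numbers for weaker inhibition), compound 2 gives 4410 nM. In this assay compound 1 gives 6180 nM. The change between them, (chloro in place of methyl on an aromatic carbon), made a 1.4-fold higher number from compound 2 to compound 1 (0.15 log units; within the scatter). For compound 3 this assay reports only a limit, > 20000 nM, which is the limit of > 20000 nM in this assay, at which 1 of the 3 values shown sits. Compound 4 carries the same change on the other core, (chloro in place of methyl on an aromatic carbon); the place of the change is described in the same words for both pairs. Because a 1.4-fold higher number from compound 2 to compound 1 (0.15 log units; within the scatter) lies within the scatter, the same change on the core of compound 3 is not expected to move the read-out beyond the scatter either, and the reading for compound 4 may again come back only as a limit. The step expected is a step that the limit leaves unreadable from compound 3 to compound 4. Compound 4 is estimated at 30000 nM, with a range from 12000 nM to 80000 nM.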

Compound 4, half-maximal inhibitory concentration: 19100 nM
Estimate against measurement, compound 4: 1.6-fold (0.20 log units) above; the range from low to high includes it.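

In this assay, chloro in place of methyl on the core of compound 3 gives an at least 1.0-fold lower number from compound 3 to compound 4 (0.01 log units; that floor lies within the scatter), which is a floor and not a measured size. Compound 3 is known only as a limit: the limit of > 20000 nM in this assay, at which 1 of the 4 values shown sits.

The change can be read as a full step only on the core of compound 1, so these data show neither that it carries across the two cores with the same size nor that it behaves differently on them: the same change on two cores in this assay, a 1.4-fold higher number (0.15 log units; within the scatter) from compound 2 to compound 1 and an at least 1.0-fold lower number (0.01 log units; that floor lies within the scatter) from compound 3 to compound 4; the limit leaves it open whether they differ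

The compounds shown hold only methyl and chloro at this place on the aryl arm, which leaves open what an amine, a methoxy group or a carboxylic acid there would do in this assay. The contribution of the differences between the two cores also stays open, as no pair shown separates them.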